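Sulfonamide-linked anilines on the oxadiazole series: compound 4

A few compounds are considered here, and "the series" means these few. Any claim that something is new, unique, unknown or untested is made for them only; others in the source may bear on it.

Values in a functional assay on MDA-MB-231 cells (Homo sapiens) for antiproliferative activity, read by MTT assay, with a stated time of 72 h (on this read-out higher numbers stand for weaker inhibition and lower numbers for stronger inhibition), so far:
Compound 1, `O=C(Nc1cccc(-c2nc(-c3ccc(NC(=O)c4cccnc4)cc3Cl)no2)c1)c1ccccc1`, gives 12800 nM.
Compound 2, `Cc1ccc(S(=O)(=O)Nc2cccc(-c3nc(-c4ccc(NC(=O)c5cccnc5)cc4Cl)no3)c2)cc1`, returns only the assay limit, > 10000 nM.
Compound 3, `CC(=O)Nc1ccc(S(=O)(=O)Nc2cccc(-c3nc(-c4ccc(NC(=O)c5cccnc5)cc4Cl)no3)c2)cc1C`, likewise returns only the assay limit, > 10000 nM.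

Compound 2 thus stands at the limit in this assay, and compound 3 sits there too; only compound 1 has a number. The step that the limit leaves unreadable from compound 1 to compound 2 cannot be sized, and a step that the two limits leave unreadable from compound 2 to compound 3 cannot be sized either, because the limit of > 10000 nM in this assay, at which 2 of the 3 values shown sit, caps both ends. Compound 4, `CCN(CC)C(=O)Nc1ccc(S(=O)(=O)Nc2cccc(-c3nc(-c4ccc(NC(=O)c5cccnc5)cc4Cl)no3)c2)cc1`, differs from compound 2 by (diethylcarbamoyl)amino in place of methyl on an aromatic carbon. The only comparable move among the measured compounds, from compound 2 to compound 3, also enlarged the group on the sulfonyl-bearing ring and left the value at the limit, so no readable step in this assay is available to carry over. With nothing to suggest a gain, compound 4 is expected to stay in the limit region as well, and any difference from compound 2 is expected to be within the scatter. The expected step from compound 2 to compound 4 in this assay is a step that the limit leaves unreadable from compound 2 to compound 4, if the assay returns a number at all. Compound 4 is estimated at 15000 nM, with a range from 6000 nM to 40000 nM.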

Compound 4, half-maximal inhibitory concentration: 8700 nM
Estimate against measurement, compound 4: 1.7-fold (0.24 log units) above; the range from low to high includes it.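

In this assay compound 4 gives 8700 nM. Among the sulfonamides shown, it is the only one to return a number rather than an assay limit. The value of compound 2, > 10000 nM, is a limit. The change of methyl to (diethylcarbamoyl)amino, on an aromatic carbon para to a large group, gives an at least 1.1-fold lower number from compound 2 to compound 4 (0.06 log units; that floor lies within the scatter), so this position can carry the larger group with the value still readable, but no real gain in potency can be claimed, because the comparison has only a limit at one end: the limit of > 10000 nM in this assay, at which 2 of the 4 values shown sit.

On these data alone, it remains open whether a plain amine or a carboxylic acid on this same aromatic carbon, or shorter or longer alkyl chains on the carbamoyl nitrogen in place of the two ethyl groups, would move the value clearly beyond the scatter. Also open, as far as these compounds go, is whether (diethylcarbamoyl)amino would have any readable effect on the benzoyl ring of compound 1, which gives 12800 nM.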